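This account rests on a few compounds, and the source may have more. Where it says the series, first, only, none or still open, it means among the compounds named here.

The compounds here share one core, shown with compound 1 `COc1cc2c(Oc3ccc(NC(=O)c4nn(-c5ccccc5)c(=O)c5ccccc45)cc3F)ccnc2cc1OCCCN1CCCC1`, which was tested in a functional assay on HT-29 cells (Homo sapiens) for cytotoxicity, read by MTT assay, with a stated time of 72 h; on this read-out lower numbers stand for stronger inhibition and higher numbers for weaker inhibition. Among the compounds with values here, compound 1 gives 980 nM in this assay, the highest number among the three compounds measured so far. Compound 2 `COc1cc2c(Oc3ccc(NC(=O)c4nn(-c5cccc(F)c5)c(=O)c5ccccc45)cc3F)ccnc2cc1OCCCN1CCCC1` gives 460 nM, and compound 3 `COc1cc2c(Oc3ccc(NC(=O)c4nn(-c5ccccc5F)c(=O)c5ccccc45)cc3F)ccnc2cc1OCCCN1CCCC1` gives 400 nM. Each differs from compound 1 only by a fluoro in place of hydrogen on an aromatic carbon, and both of those steps lowered the number: a 2.1-fold lower number from compound 1 to compound 2 (0.33 log units; beyond the scatter) and a 2.5-fold lower number from compound 1 to compound 3 (0.39 log units; beyond the scatter). Between the two fluoro placements, a 1.2-fold lower number from compound 2 to compound 3 (0.06 log units; within the scatter).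

Compound 4 `COc1cc2c(Oc3ccc(NC(=O)c4nn(-c5ccccc5)c(=O)c5ccccc45)cc3F)ccnc2cc1OCCCN1CCN(C)CC1` has not been measured. It differs from compound 1 at a different place altogether: 4-methylpiperazin-1-yl in place of pyrrolidin-1-yl on a saturated chain carbon, three bonds along the chain from an oxygen on an aromatic ring. None of the three measured steps touches this part of the molecule; all three concern a fluoro on an aromatic carbon, so they give no direct guide to the size or direction of this change. With nothing measured that bears on it, the plainest expectation is that compound 4 stays close to compound 1, with no step beyond the scatter. The estimate for compound 4 is therefore 950 nM, within a range of 400 nM to 2300 nM. The expected step is a 1.0-fold lower number from compound 1 to compound 4 (0.01 log units; within the scatter).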

Compound 4, half-maximal inhibitory concentration: 1140 nM
Estimate against measurement, compound 4: 1.2-fold (0.08 log units) below, within the range that was stated.
By their numbers in this assay, from the lowest: compounds 3 and 2 (each within the scatter of the next); then compounds 1 and 4 (each within the scatter of the next).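

In this assay, putting 4-methylpiperazin-1-yl in place of pyrrolidin-1-yl on the saturated chain carbon, three bonds along the chain from an oxygen on an aromatic ring, gives a 1.2-fold higher number from compound 1 to compound 4 (0.07 log units; within the scatter), so this swap of a five-membered ring with one hetero atom for a six-membered ring with two leaves the number within the usual scatter. Within the data shown here, this is the first view of this part of the molecule, since the earlier steps concerned only a fluoro on an aromatic carbon, and unlike those two steps from compound 1, this one shows no change that can be told apart from repeat-measurement noise. No measurement shown here offers an explanation for this result.

On these data alone, the result rests on a single pair, so it remains open whether the same swap would behave alike in the fluoro-bearing compound 2 or compound 3. Also open, as far as these compounds go, is how a morpholin-4-yl ring, an open-chain dimethylamino group or a longer chain, such as a 4-(pyrrolidin-1-yl)butyl group in place of the 3-(pyrrolidin-1-yl)propyl group, would read in this assay.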